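Aryl substituent series: chloro to nitro

A few compounds are considered here, and "the series" means these few. Any claim that something is new, unique, unknown or untested is made for them only; others in the source may bear on it.

Compound 1 `Nc1nc(N2CCCCC2)sc1C(=O)/C=C/c1ccccc1` gives 28.1 ug/mL in a functional assay on SW480 cells (Homo sapiens) for antiproliferative activity, read by MTT assay, with a stated time of 48 h; on this read-out higher numbers stand for weaker inhibition and lower numbers for stronger inhibition. Compound 2 `Nc1nc(N2CCCCC2)sc1C(=O)/C=C/c1ccc(Cl)cc1` gives 29.4 ug/mL, and compound 3 `Nc1nc(N2CCCCC2)sc1C(=O)/C=C/c1ccc(Cl)cc1Cl` gives 36.8 ug/mL. Compound 2 stands second highest of the three numbers; the steps of a 1.0-fold higher number from compound 1 to compound 2 (0.02 log units; within the scatter) and a 1.3-fold higher number from compound 2 to compound 3 (0.10 log units; within the scatter) lie within the scatter, as does a 1.3-fold higher number from compound 1 to compound 3 (0.12 log units; within the scatter). Compound 4 `Nc1nc(N2CCCCC2)sc1C(=O)/C=C/c1ccc([N+](=O)[O-])cc1` differs from compound 2 by nitro in place of chloro on an aromatic carbon, a nitro in place of chloro on an aromatic carbon, para to a large group. Going by the values given here, no measured step involves a nitro; the steps that bear on this change are the chloro additions, a 1.0-fold higher number from compound 1 to compound 2 (0.02 log units; within the scatter) and a 1.3-fold higher number from compound 2 to compound 3 (0.10 log units; within the scatter), both within the scatter. In this assay compound 4 is therefore expected to show no step beyond the scatter, a 1.0-fold higher number from compound 2 to compound 4 (0.01 log units; within the scatter). The estimate for compound 4 is 30 ug/mL, with a range from 15 ug/mL to 60 ug/mL.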

Compound 4, half-maximal inhibitory concentration: 25.6 ug/mL
Beside the measured number, compound 4's estimate is 1.2-fold (0.07 log units) above it; the range from low to high includes it.
By their numbers in this assay, from the lowest: compounds 4, 1, 2 and 3 (each within the scatter of the next).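

In this assay, nitro on this aromatic carbon, para to a large group, behaves like chloro and hydrogen: a 1.1-fold lower number from compound 2 to compound 4 (0.06 log units; within the scatter) and a 1.1-fold lower number from compound 1 to compound 4 (0.04 log units; within the scatter) both stay within the scatter. The larger nitro, with its hydrogen-bond acceptors, thus brings no readable change at this place, and compounds 1, 2 and 4 cannot be told apart. No measurement shown offers a reason for this flat result.

On these data alone, whether an amine or a carboxylic acid at this carbon would move the number beyond the scatter stays open. As far as these compounds go, all four compounds share the core of compound 1, so the effect of changing it also stays open.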